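Trimming a Long Chain When Every Value Sits at the Limit

The source may hold more compounds than are shown below. What is called first, only, known or untested is meant among the compounds shown, and "the series" means these compounds.

Of the compounds shown here, three have been tested in an assay on isolated protein for inhibition of ATP-dependent RNA helicase SUPV3L1, mitochondrial (Homo sapiens); on this read-out higher numbers stand for weaker inhibition and lower numbers for stronger inhibition. Compound 1 `CCCCCCCCCCCCNc1nc(O)c2ncnc-2c(O)n1` gives > 500 ug/mL, which is a limit of the assay and not a number. Compound 2 `CCCCCCCCCCCCCCCCNc1nc(=O)c2ncn([C@@H]3O[C@H](CO)[C@@H](O)[C@H]3O)c2c(=O)[nH]1`, which carries a longer saturated chain on a different core, also reaches only the limit in this assay, giving > 500 ug/mL. Compound 3 `O=c1nc(Nc2ccccc2)[nH]c(=O)c2c1ncn2C1O[C@H](CO)[C@@H](O)[C@H]1O`, with a phenyl in place of a chain, likewise gives only the limit, > 500 ug/mL. Compound 2 therefore stands where every measured compound stands: at the limit of > 500 ug/mL in this assay, at which 3 of the 3 values shown sit, with nothing separating it from compound 1 or compound 3.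

Compound 4 `CCCCCCCCCCCCNc1nc(=O)c2ncn([C@@H]3O[C@H](CO)[C@@H](O)[C@H]3O)c2c(=O)[nH]1` differs from compound 2 in one place: hydrogen in place of butyl on a saturated chain carbon, ten or more bonds along the chain from a nitrogen on an aromatic ring. For the measured compounds named here, no pair of measured compounds differs in a single place, so no measured step shows what this change does in this assay. Since compound 1, which carries the same shorter chain, also sits at the limit of > 500 ug/mL in this assay, at which 3 of the 3 values shown sit, the expected step is a step that the limit leaves unreadable from compound 2 to compound 4, none beyond the usual scatter. For compound 4 the estimate in this assay is 600 ug/mL, within a range from 200 ug/mL to 2000 ug/mL, most likely reported once more only as a limit.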

Compound 4, half-maximal inhibitory concentration: > 500 ug/mL
Compound 4 gave a limit, no number; the forecaster's own chance of this, stated with the estimate: 85%; the middle value is on the limit's open side.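

For the compounds shown here, compound 2 and compound 4 both stop at a limit in this assay rather than at a number, so no step between them can be read. The compounds shown leave open whether hydrogen in place of butyl changes inhibition at all, and which structure would give a readable value.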